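The compounds below may be only part of what the source reports. "The series", "measured", "known", "first", "only" and "open" are said of these compounds alone.

In a functional assay on HCT-116 cells (Homo sapiens) for cytotoxicity, read by resazurin assay, with a stated time of 48 h (a lower number here means that less compound is needed, a higher number that more compound is needed for the effect), compound 1 `O=S(=O)(Nc1ccc(-c2nc3cc(NS(=O)(=O)c4ccc(Cl)s4)ccc3o2)cc1)c1ccc(Cl)c(C(F)(F)F)c1` gives 17000 nM and compound 2 `O=S(=O)(Nc1ccc(-c2nc3cc(NS(=O)(=O)c4ccc(Br)cc4)ccc3o2)cc1)c1ccc(Br)cc1` gives 11000 nM, so the two stand within the usual scatter of each other. Compound 3 `O=S(=O)(Nc1ccc(-c2nc3cc(NS(=O)(=O)c4ccc(Cl)s4)ccc3o2)cc1)c1ccc(Cl)s1` shares the core of compound 1 but carries 5-chlorothiophen-2-yl in place of 4-chloro-3-(trifluoromethyl)phenyl on a sulfonyl sulfur. Within the data shown here, no step between measured compounds informs this change, so no shift beyond the scatter is expected in this assay, and the estimated step is a 1.4-fold lower number from compound 1 to compound 3 (0.15 log units; within the scatter). For compound 3 the estimated value is 12000 nM, with an expected range of 5000 nM to 30000 nM.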

Compound 3, half-maximal effective concentration: 15000 nM
Beside the measured number, compound 3's estimate is 1.3-fold (0.10 log units) below it; the measured number falls inside the stated range.
By their numbers in this assay, from the lowest: compounds 2, 3 and 1 (each within the scatter of the next).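

Among these compounds, the first step at this position comes with 5-chlorothiophen-2-yl in place of 4-chloro-3-(trifluoromethyl)phenyl on a sulfonyl sulfur, which gives a 1.1-fold lower number from compound 1 to compound 3 (0.05 log units; within the scatter) in this assay and stays within the scatter. At this position, then, a five-membered aromatic ring with 1 hetero atom and 6 heavy atoms serves as well in this read-out as a six-membered aromatic ring of carbon only with 11 heavy atoms. No measurement available here bears on the reason for this result. As far as these compounds go, whether an amine or a carboxylic acid in this place would move the number beyond the scatter stays open.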